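A Pyridine Swap on a Weakly Antiproliferative Oxadiazole

The source may hold more compounds than are shown below. What is called first, only, known or untested is meant among the compounds shown, and "the series" means these compounds.

The three compounds were tested in a functional assay on MCF7 cells (Homo sapiens) for antiproliferative activity, read by MTT assay, with a stated time of 24 h; on this read-out higher numbers stand for weaker inhibition and lower numbers for stronger inhibition. Within the data shown here, compound 2 `COc1ccc(-c2noc(-c3ccc(Cl)cc3)n2)cc1OC1CCCC1` is the only member with a measured number, giving 174000 nM in this assay. Compound 1 `c1ccc(-c2noc(-c3ccncc3)n2)cc1` reaches only the limit of > 1000000 nM in this assay. Compound 3 `Fc1ccc(-c2nc(-c3ccccc3)no2)cc1` also sits at the limit of > 1000000 nM in this assay. In short, (the limit of > 1000000 nM in this assay, at which 2 of the 3 values shown sit). Compound 4 `COc1ccc(-c2noc(-c3ccncc3)n2)cc1OC1CCCC1` is not yet measured; it differs from compound 2 by pyridin-4-yl in place of 4-chlorophenyl on an aromatic carbon. Compound 1 carries the same pyridin-4-yl group and reaches only the limit of > 1000000 nM. On that basis compound 4 is expected to lose activity by a step beyond the scatter, a 3.4-fold higher number from compound 2 to compound 4 (0.54 log units; beyond the scatter). Compound 4 is therefore estimated at 600000 nM, within 150000 nM to 2000000 nM, with a real chance that only a limit is reported.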

Compound 4, half-maximal inhibitory concentration: > 1000000 nM
Compound 4: only a limit was reported (the forecaster's own chance of this, stated with the estimate: 50%); at least 1.6-fold (0.22 log units) between middle value and limit.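

At this place on the five-membered ring, pyridin-4-yl in place of 4-chlorophenyl gives, in this assay, an at least 5.7-fold higher number from compound 2 to compound 4 (0.75 log units; beyond the scatter). Among these compounds, this is the first step that can be read, and it shows that the rest of compound 2 does not hold its activity once 4-chlorophenyl has gone. The value for compound 4 is a limit, not a number, and it joins the others there: the limit of > 1000000 nM in this assay, at which 3 of the 4 values shown sit.

On these data alone, the full size of the step therefore stays open. Also open, as far as these compounds go, is whether a phenyl ring carrying an amine or a carboxylic acid in place of the chlorine would keep the activity of compound 2.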